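Fluoro for Chloro: What Compound 4 Might Show

The source may hold more compounds than are shown below. What is called first, only, known or untested is meant among the compounds shown, and "the series" means these compounds.

Three compounds built on one shared core have been examined in an ADME assay on Vero cells (Chlorocebus sabaeus) for cytotoxicity; on this read-out lower numbers stand for higher toxicity in this test and higher numbers for lower toxicity in this test. Compound 1 `Cc1ccsc1[C@@H]1C[C@H](O)Cc2cc(Cl)ccc2N1` gives 200000 nM. Compound 2 `Cc1ccsc1[C@@H]1C[C@H](O)Cc2cc(F)ccc2N1` differs from compound 1 by fluoro in place of chloro on an aromatic carbon; in this assay compound 2 gives 243000 nM, so that a 1.2-fold higher number from compound 1 to compound 2 (0.08 log units; within the scatter). Compound 3 `Cc1ccc([C@@H]2C[C@H](O)Cc3cc(Cl)ccc3N2)o1` differs from compound 1 by 5-methylfuran-2-yl in place of 3-methylthiophen-2-yl on a saturated ring carbon; in this assay compound 3 gives 300000 nM, a step of a 1.5-fold higher number from compound 1 to compound 3 (0.18 log units; within the scatter). All three numbers sit within the scatter of one another, so no order among them can be read.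

Compound 4 `Cc1ccc([C@@H]2C[C@H](O)Cc3cc(F)ccc3N2)o1` has not yet been measured in this assay. Its relation to compound 3 is fluoro in place of chloro on an aromatic carbon, the same change that led from compound 1 to compound 2, at a place described in the same words; the two cores differ as given by 5-methylfuran-2-yl in place of 3-methylthiophen-2-yl on a saturated ring carbon.

Because a 1.2-fold higher number from compound 1 to compound 2 (0.08 log units; within the scatter), compound 4 is expected to sit close to compound 3, with an estimated step of a 1.1-fold higher number from compound 3 to compound 4 (0.04 log units; within the scatter). The expected value for compound 4 is 330000 nM, estimated to lie between 160000 nM and 650000 nM.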

Compound 4, half-maximal cytotoxic concentration: 823000 nM
Estimate against measurement, compound 4: 2.5-fold (0.40 log units) below; the measured number lies above the stated range.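

In this assay, fluoro in place of chloro gives a 2.7-fold higher number from compound 3 to compound 4 (0.44 log units; beyond the scatter), and 5-methylfuran-2-yl in place of 3-methylthiophen-2-yl gives a 3.4-fold higher number from compound 2 to compound 4 (0.53 log units; beyond the scatter). The fluoro step lies beyond the scatter on one core and within it on the other, yet the two steps cannot be told apart, so these compounds neither show that the core alters the step nor establish that it carries over unchanged: the same change on two cores in this assay, a 1.2-fold higher number (0.08 log units; within the scatter) from compound 1 to compound 2 and a 2.7-fold higher number (0.44 log units; beyond the scatter) from compound 3 to compound 4, 2.3-fold (0.35 log units) apart, within the scatter of two such steps. The exchange of the ring group reads the same way, and a single pair of cores says nothing about how either change would behave on any other core: the same change on two cores in this assay, a 1.5-fold higher number (0.18 log units; within the scatter) from compound 1 to compound 3 and a 3.4-fold higher number (0.53 log units; beyond the scatter) from compound 2 to compound 4, 2.3-fold (0.35 log units) apart, within the scatter of two such steps.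

From the compounds shown here alone, it remains open whether the larger step seen with fluoro would recur with a bromo group or a nitrile on that aromatic carbon, or with a phenyl group or an amine on the saturated ring carbon. The four compounds also speak only to this one read-out, leaving any other effect of these changes unaddressed.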